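The source may report more compounds than this note shows. Statements on the series, on what has been measured and on what is new or still open speak of the compounds shown alone.

Measured compounds:
Compound 1 `CCCn1c(=O)c2nc([C@@H]3CC4C=CC3C4)[nH]c2n(CCC)c1=O` — in an assay on cell membranes for binding affinity to adenosine receptor A1 (Cavia porcellus), read by radioligand binding (on this read-out lower numbers stand for stronger inhibition and higher numbers for weaker inhibition), compound 1 gives 4.3 nM
Compound 2 `CCCn1c(=O)c2nc([C@H]3CC4C=CC3C4)[nH]c2n(CCC)c1=O` — in this assay compound 2 gives 3.4 nM
Compound 3 `CCCn1c(=O)c2nc(-c3nn[nH]n3)[nH]c2n(CCC)c1=O` — not yet measured

Among the measured compounds shown here, compound 2 gives the lowest of the two numbers so far, but the step of a 1.3-fold lower number from compound 1 to compound 2 (0.10 log units; within the scatter) is within the scatter, so the two compounds are not distinguished by these data. For the measured compounds named here, the only measured step concerns a stereocentre at a saturated ring carbon and leaves the rest of the molecule unchanged; it therefore says nothing about what happens when the substituent itself is exchanged.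

Compound 3 differs from compound 2 by a group of 5 heavy atoms (1 carbon, 4 nitrogen; one five-membered aromatic ring with 4 hetero atoms) in place of a group of 7 heavy atoms (7 carbon; 2 five-membered non-aromatic rings of carbon only), on an aromatic carbon. Going by the values given here, no measured pair shows a change of this kind, so the expectation rests on the structural change alone and is correspondingly uncertain. The hydrocarbon bicycle gives way to a small aromatic heterocycle carrying one hydrogen-bond donor and three acceptors, and a weakening of binding is expected, that is, a higher number in this assay for compound 3, estimated as a 180-fold higher number from compound 2 to compound 3 (2.25 log units; beyond the scatter). Compound 3 is therefore expected to give about 600 nM, within a range from 60 nM to 6000 nM.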

Compound 3, inhibition constant: > 10000 nM
Compound 3: no number, only a limit; the forecaster's own chance of this, stated with the estimate: 10%; middle value at least 16-fold (1.22 log units) away from the limit.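

Compared with the earlier step at the stereocentre, which stayed within the scatter, this exchange shows that the group on this aromatic carbon matters a great deal. Putting 2H-tetrazol-5-yl in place of the all-carbon group gives an at least 2900-fold higher number from compound 2 to compound 3 (3.46 log units; beyond the scatter) and likewise an at least 2300-fold higher number from compound 1 to compound 3 (3.36 log units; beyond the scatter) in what is a large change from either drawn configuration. In this assay compound 3 gives > 10000 nM, which is a limit of the assay and not a number, so both steps are bounded rather than exact: the limit of > 10000 nM in this assay, at which 1 of the 3 values shown sits.

The compounds shown leave open how far compound 3 lies past that limit, and whether the change follows from losing the all-carbon group or from bringing in the 2H-tetrazol-5-yl ring. They also do not tell how a cyclopentyl group or a carboxylic acid on this carbon would behave.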